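The source may hold more compounds than are shown below. What is called first, only, known or untested is meant among the compounds shown, and "the series" means these compounds.

Compound 3 `CCCCCCCCCCn1c(=O)n(C2OC(CO)[C@@H](O)[C@H]2O)c2nc(N)nc(O)c21` gives the lowest of the three values in a functional assay on the whole organism (B cells) with Mus musculus as the target (a higher number here means a larger maximal response, a lower number a smaller maximal response), at 0%. Compound 1 `Nc1nc(O)c2c(n1)n(C1OC(CO)[C@@H](O)[C@H]1O)c(=O)n2Cc1ccc(Cl)c(Cl)c1` gives 55% and compound 2 `Nc1nc(O)c2c(n1)n(C1OC(CO)[C@@H](O)[C@H]1O)c(=O)n2CC(O)CSc1ccccc1` gives 12%. Every measured step alters the same position: a number 43 percentage points lower from compound 1 to compound 2 (beyond the scatter), a number 55 percentage points lower from compound 1 to compound 3 (beyond the scatter) and a number 12 percentage points lower from compound 2 to compound 3 (beyond the scatter). Compound 4 `NC(=O)Cn1c(=O)n(C2OC(CO)[C@@H](O)[C@H]2O)c2nc(N)nc(O)c21` differs from compound 3 by carbamoyl in place of nonyl on a saturated chain carbon bound to an aromatic nitrogen. Within the data shown here, no measured step introduces a carbamoyl group, so the three steps show only that changes at this position move the maximal response strongly; since compound 3 already gives 0%, the expected step cannot run lower. The account therefore expects a small rise, a number 10 percentage points higher from compound 3 to compound 4 (within the scatter), with wide uncertainty. The estimate for compound 4 is 10%, between 0% and 40%.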

Compound 4, largest response reached (reported as maximal response), in percent of the reference or control that the assay uses: 32%
The estimate for compound 4 lay 22 percentage points below the measured number, within the range that was stated.
By their numbers in this assay, from the lowest: compound 3; then compound 2; then compound 4; then compound 1.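

In this assay, carbamoyl in place of nonyl gives a large rise at this position, with a number 32 percentage points higher from compound 3 to compound 4 (beyond the scatter). The carbamoyl compound also ranks above the 1-hydroxy-2-(phenylsulfanyl)ethyl compound, with a number 20 percentage points higher from compound 2 to compound 4 (beyond the scatter), but stays short of the 3,4-dichlorophenyl compound, with a number 23 percentage points lower from compound 1 to compound 4 (beyond the scatter). A ring in the group therefore does not decide the order: compound 4 has none, yet it exceeds ring-bearing compound 2.

On these data alone, whether a carboxylic acid or an amine at this place would match carbamoyl remains open. Nothing available explains these differences.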